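Working notes: methyl to bromo on the sulfonyl aryl ring

This account rests on a few compounds, and the source may have more. Where it says the series, first, only, none or still open, it means among the compounds named here.

Measured compounds:
Compound 1 `COc1cc(Nc2nc3ccccc3nc2S(=O)(=O)c2ccc(C)cc2)cc(OC)c1` gives 8060 nM in a functional assay on A549 cells (Homo sapiens) for cytotoxicity, read by MTT assay, with a stated time of 72 h; on this read-out lower numbers stand for stronger inhibition and higher numbers for weaker inhibition.
Compound 2 `COc1cc(Nc2nc3ccccc3nc2S(=O)(=O)c2ccc(C)cc2)cc(OC)c1OC` gives 5610 nM in this assay.

Going by the values given here, compound 2 stands with the lower of the two numbers, its nearest neighbour being compound 1; the only step between measured compounds, a 1.4-fold lower number from compound 1 to compound 2 (0.16 log units; within the scatter), comes from a methoxy in place of hydrogen on an aromatic carbon of the aniline ring and stays within the scatter. The two compounds therefore cannot be ordered against each other in this assay.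

Compound 3 `COc1cc(Nc2nc3ccccc3nc2S(=O)(=O)c2ccc(Br)cc2)cc(OC)c1OC` is the next member and differs from compound 2 by bromo in place of methyl on an aromatic carbon. Among the compounds with values here, no measured step touches this ring: the one step on record concerns the methoxy pattern on the other ring, and it was itself within the scatter. Within the data shown here, nothing in the numbers so far points to a change of either sign from exchanging the methyl for bromo on the sulfonyl aryl ring.

Accordingly, compound 3 is expected to land close to compound 2, with a step of a 1.1-fold lower number from compound 2 to compound 3 (0.05 log units; within the scatter) in this assay. The estimate for compound 3 is 5000 nM, with a range from 1500 nM to 16000 nM.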

Compound 3, half-maximal inhibitory concentration: 6110 nM
Compound 3: middle estimate off by 1.2-fold (0.09 log units), on the low side, within the range that was stated.
By their numbers in this assay, from the lowest: compounds 2, 3 and 1 (each within the scatter of the next).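

The para place on the sulfonyl aryl ring now has its first measured step: in this assay, the exchange of 4-methylphenyl for 4-bromophenyl gives a 1.1-fold higher number from compound 2 to compound 3 (0.04 log units; within the scatter) and stays within the scatter. The methyl and bromo forms of this ring therefore cannot be ordered against each other, and the series now holds one step within the scatter on each aryl ring, the other being a 1.4-fold lower number from compound 1 to compound 2 (0.16 log units; within the scatter) on the aniline ring. No supporting data bear on the reason for this result.

Methyl and bromo are the only groups shown at this place, so it remains open whether an amine, a carboxylic acid or a longer chain such as n-butyl there would move the number beyond the scatter in this assay at all. Also open is whether bromo at this place would read the same on the aniline ring of compound 1, since the bromo step is shown only with the aniline ring of compound 2.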